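A Methoxy Group Tried on a Second Core

A few compounds are considered here, and "the series" means these few. Any claim that something is new, unique, unknown or untested is made for them only; others in the source may bear on it.

Measured compounds:
Compound 1, `C=C(C)[C@@H]1CC=C(Cn2cc(COc3ccc(C4NC(=O)NC(C)=C4C(C)=O)cc3)nn2)CC1`: 20000 nM
Compound 2, `C=C(C)[C@@H]1CC=C(Cn2cc(COc3ccc(C4NC(=O)NC(C)=C4C(C)=O)cc3OC)nn2)CC1`: 77900 nM
Compound 3, `C=C(C)[C@@H]1CC=C(Cn2cc(COc3ccc(C4NC(=O)NC5=C4C(=O)CC(C)(C)C5)cc3)nn2)CC1`: 6610 nM

All three were tested in a functional assay on U-251 cells (Homo sapiens) for inhibition, read by sulforhodamine B assay, with a stated time of 48 h; on this read-out lower numbers stand for stronger inhibition of growth and higher numbers for weaker inhibition of growth. Compound 3 gives the lowest number of the three, and the difference between its core and the core of compound 1 is not broken down here. Going from compound 1 to compound 2 brought a 3.9-fold higher number from compound 1 to compound 2 (0.59 log units; beyond the scatter), the change being (methoxy in place of hydrogen on an aromatic carbon).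

Compound 4, `C=C(C)[C@@H]1CC=C(Cn2cc(COc3ccc(C4NC(=O)NC5=C4C(=O)CC(C)(C)C5)cc3OC)nn2)CC1`, is not yet measured. It differs from compound 3 by methoxy in place of hydrogen on an aromatic carbon, the same change as before, at the same kind of place. Among the compounds with values here, the expected step is a 3.3-fold higher number from compound 3 to compound 4 (0.52 log units; beyond the scatter), resting on the single earlier example because a 3.9-fold higher number from compound 1 to compound 2 (0.59 log units; beyond the scatter) was seen once and may not carry over unchanged. Compound 4 is therefore estimated at 22000 nM, within a range from 8000 nM to 60000 nM.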

Compound 4, concentration for total growth inhibition: 44000 nM
Compound 4: middle estimate off by 2.0-fold (0.30 log units), on the low side, within the range that was stated.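

In this assay, putting the methoxy group on the core of compound 3 again weakened growth inhibition, giving a 6.7-fold higher number from compound 3 to compound 4 (0.82 log units; beyond the scatter). The change therefore acted in the same direction on both cores, and the sizes of the two steps cannot be told apart: the same change on two cores in this assay, a 3.9-fold higher number (0.59 log units; beyond the scatter) from compound 1 to compound 2 and a 6.7-fold higher number (0.82 log units; beyond the scatter) from compound 3 to compound 4, 1.7-fold (0.23 log units) apart, within the scatter of two such steps. Within the data shown here, with only two pairs in one cell line, this shows that the change carried over between these two cores, but not that it would carry over to others, nor why it weakens inhibition.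

The compounds shown leave open whether another group on the same aromatic carbon, such as a hydroxyl, a fluorine or an amine, would behave like methoxy. They also leave open what a methoxy group would do on a different carbon of that ring.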